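This account rests on a few compounds, and the source may have more. Where it says the series, first, only, none or still open, it means among the compounds named here.

In an assay on isolated protein for inhibition of matrix metalloproteinase-9 (Homo sapiens) (on this read-out lower numbers stand for stronger inhibition and higher numbers for weaker inhibition), three compounds have been measured:

Compound 1 `C=C[C@@H]1OC(c2ccc(Cl)cc2)=N[C@H]1CO` gives 33000 nM.
Compound 2 `C=C[C@@H]1OC(c2ccc(-c3ccccc3)cc2)=N[C@H]1Sc1ccccc1` gives > 100000 nM, which is a limit of the assay and not a number.
Compound 3 `C=C[C@@H]1OC(c2ccc(-c3ccccc3)cc2)=N[C@H]1CO` gives 24000 nM.

Compound 3 therefore holds the lower of the two numbers, and its nearest neighbour is compound 1, whose value sits within the scatter of it (a 1.4-fold lower number from compound 1 to compound 3 (0.14 log units; within the scatter)). Compound 4 `C=C[C@@H]1OC(c2ccccc2)=N[C@H]1CO` differs from compound 3 in one place: hydrogen in place of phenyl on an aromatic carbon. The step that bears on this change is the one at the same aromatic carbon, from chloro to phenyl, which moved the value only within the scatter (a 1.4-fold lower number from compound 1 to compound 3 (0.14 log units; within the scatter)). The step from compound 2 to compound 3 changes a different position and does not inform the exchange. Since the para group has so far mattered little, compound 4 is expected to give a number close to that of compound 3, at most slightly higher, a step of a 1.9-fold higher number from compound 3 to compound 4 (0.27 log units; within the scatter). The estimate for compound 4 is 45000 nM, with a range from 15000 nM to 150000 nM.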

Compound 4, inhibition constant: > 4000000 nM
Compound 4 was reported as a limit (the forecaster's own chance of this, stated with the estimate: 25%); at least 88-fold (1.94 log units) between middle value and limit.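

Compound 4 stands at a limit of the assay and not a number: the limit of > 4000000 nM in this assay, at which 1 of the 4 values shown sits. Even so, in this assay this aromatic carbon turns out to matter a great deal: hydrogen in place of phenyl gives an at least 160-fold higher number from compound 3 to compound 4 (2.22 log units; beyond the scatter), and hydrogen in place of chloro gives an at least 120-fold higher number from compound 1 to compound 4 (2.08 log units; beyond the scatter). The earlier step from chloro to phenyl had shown only that those two groups read alike within the scatter, and only now is it seen that either of them, set against hydrogen, goes with far lower numbers.

The compounds shown leave open what an amine, a carboxylic acid or a methoxy group at this place would give, and whether any such group would reach lower numbers than chloro or phenyl. They also leave open whether hydrogen has the same effect when phenylsulfanyl stands in place of hydroxymethyl on the saturated ring carbon.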